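Removing a methyl group after a large gain

The compounds below may be only part of what the source reports. "The series", "measured", "known", "first", "only" and "open" are said of these compounds alone.

Compound 1, `CC1=NNC(=O)C1C(c1c(-c2ccccc2)[nH]c2ccc(C)cc12)c1c(-c2ccccc2)[nH]c2ccc(C)cc12`, gives 32700 nM in a functional assay on HeLa cells (Homo sapiens) for cytotoxicity, read by MTT assay; on this read-out higher numbers stand for weaker inhibition and lower numbers for stronger inhibition.
Compound 2, `CC1=NNC(=O)C1C(c1c(-c2ccccc2)[nH]c2ccccc12)c1c(-c2ccccc2)[nH]c2ccc(C)cc12`, gives > 100000 nM in this assay; this is a limit of the assay, not a number.
Compound 3, `CC1=NNC(=O)C1C(c1c[nH]c2ccccc12)c1c(-c2ccccc2)[nH]c2ccc(C)cc12`, gives 2400 nM in this assay.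

Compound 3 gives the lowest of the two real numbers, with compound 1 clearly higher; compound 2 sits at the limit of > 100000 nM in this assay, at which 1 of the 3 values shown sits. Compound 4, `CC1=NNC(=O)C1C(c1c[nH]c2ccccc12)c1c(-c2ccccc2)[nH]c2ccccc12`, awaits measurement. It differs from compound 3 by hydrogen in place of methyl on an aromatic carbon. Going by the values given here, the only measured step of this kind gave an at least 3.0-fold higher number from compound 1 to compound 2 (0.48 log units; beyond the scatter), and the large drop an at least 41-fold lower number from compound 2 to compound 3 (1.61 log units; beyond the scatter) concerned a different group. An at least modest rise in this assay is therefore expected from compound 3 to compound 4, a 2.9-fold higher number from compound 3 to compound 4 (0.46 log units; beyond the scatter). Compound 4 is estimated at 7000 nM, within a range from 2000 nM to 25000 nM.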

Compound 4, half-maximal inhibitory concentration: 7700 nM
Beside the measured number, compound 4's estimate is 1.1-fold (0.04 log units) below it; low and high end bracket the measured number.
By their numbers in this assay, from the lowest: compound 3; then compound 4; then compound 1. At a limit, above all of these: compound 2.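

In this assay, hydrogen in place of methyl brings a 3.2-fold higher number from compound 3 to compound 4 (0.51 log units; beyond the scatter), so the rise seen earlier also appears on a second core. Going by these compounds alone, both ends of this step are real numbers, which gives the change a measured size for the first time, whereas the earlier step ended at a limit. The two steps can now be set side by side: the same change on two cores in this assay, an at least 3.0-fold higher number (0.48 log units; beyond the scatter) from compound 1 to compound 2 and a 3.2-fold higher number (0.51 log units; beyond the scatter) from compound 3 to compound 4; the limit leaves it open whether they differ

On these data alone, whether an ethyl chain, a methoxy group or an amine at this position would give a lower number than methyl stays open.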